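The source may hold more compounds than are shown below. What is called first, only, known or untested is meant among the compounds shown, and "the series" means these compounds.

Compounds measured in an assay for inhibition of tyrosine-protein kinase Mer (Homo sapiens), read by 33P incorporation, in the presence of a further agent that is not named here; a lower number here means a stronger inhibitor, a higher number a weaker inhibitor:
compound 1 `CNc1ncc2c(-c3ccc(N4CCNCC4)nc3)nn(CC3CCCC3)c2n1` gives 640 nM
compound 2 `CNc1ncc2c(-c3ccc(N4CCN(C)CC4)nc3)nn(Cc3cn(Cc4ccccc4)nn3)c2n1` gives 2000 nM
compound 3 `CCN1CCN(c2ccc(-c3nn(Cc4cn(Cc5ccccc5)nn4)c4nc(NC)ncc34)cn2)CC1` gives a limit of > 10000 nM

Among the two numbers that are numbers, compound 2 stands at the higher one; compound 1 gives the lower number, and the gap between them lies beyond the scatter. Compound 3 reports only a limit of the assay, and one of the three values sits there (the limit of > 10000 nM in this assay, at which 1 of the 3 values shown sits). For the measured compounds named here, the one single-place step that has been measured, an at least 5.0-fold higher number from compound 2 to compound 3 (0.69 log units; beyond the scatter), concerns the piperazine nitrogen and not the group on the aromatic nitrogen, so it gives no direct guide to the change at hand.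

Compound 4 `CNc1ncc2c(-c3ccc(N4CCN(C)CC4)nc3)nn(CC3CCCC3)c2n1` is not yet measured. It differs from compound 2 in one place: cyclopentyl in place of 1-benzyl-1H-1,2,3-triazol-4-yl on a saturated chain carbon bound to an aromatic nitrogen. Going by the values given here, no measured step covers this exchange. What the data do show is that compound 1, which carries the cyclopentyl group on the same saturated chain carbon, gives 640 nM, while compound 2 gives 2000 nM; compound 1 and compound 4 differ only at the piperazine nitrogen. On that basis the step of a 3.3-fold lower number from compound 2 to compound 4 (0.52 log units; beyond the scatter) is expected to run toward a lower number, of a size beyond the scatter. Compound 4 is therefore estimated at 600 nM, within 200 nM to 1800 nM.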

Compound 4, half-maximal inhibitory concentration: 480 nM
Beside the measured number, compound 4's estimate is 1.3-fold (0.10 log units) above it; the range from low to high includes it.
By their numbers in this assay, from the lowest: compounds 4 and 1 (each within the scatter of the next); then compound 2. At a limit, above all of these: compound 3.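

In this assay, the exchange on a saturated chain carbon bound to an aromatic nitrogen can now be read directly as one change, with the methyl-bearing piperazine held the same (a 4.2-fold lower number from compound 2 to compound 4 (0.62 log units; beyond the scatter)). The 1-benzyl-1H-1,2,3-triazol-4-yl group, with 12 heavy atoms and two aromatic rings, gives way here to cyclopentyl with 5 heavy atoms, so at this position the full benzyl-triazole group is not needed for a number in this range. With cyclopentyl in place, methyl in place of hydrogen on an amine nitrogen in a ring gives two values that lie within the scatter of each other (a 1.3-fold lower number from compound 1 to compound 4 (0.12 log units; within the scatter)), so this methyl makes no readable difference in that setting.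

The compounds shown leave open which part of the departing group accounts for the step, and whether a cyclohexyl, a phenyl or a 1-methyl-1H-1,2,3-triazol-4-yl group on the same carbon would stand with cyclopentyl or with the benzyl-triazole group. Nothing measured here gives a reason for the step at this position.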